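Methyl to nitro, starting from a limit

The compounds below may be only part of what the source reports. "The series", "measured", "known", "first", "only" and "open" are said of these compounds alone.

Measured in a functional assay on the whole organism for inhibition, with Rattus norvegicus as the target (on this read-out lower numbers stand for an effect already at smaller amounts and higher numbers for an effect only at larger amounts of compound), so far
- compound 1 `COc1cccc(N2CCN(CCCCN3C(=O)CC(C)(C)CC3=O)CC2)n1` gives 76.2 mg/kg
- compound 2 `Cc1cccnc1N1CCN(CCCCN2C(=O)SC3(CCCC3)C2=O)CC1` gives > 50 mg/kg as a limit, not a number
- compound 3 `COC(=O)c1cccnc1N1CCN(CCCCN2C(=O)SC3(CCCC3)C2=O)CC1` gives 50.2 mg/kg

Compound 2 stands only at the limit > 50 mg/kg with no exact number. Compound 4 `O=C1SC2(CCCC2)C(=O)N1CCCCN1CCN(c2ncccc2[N+](=O)[O-])CC1` alters compound 2 in one place, from 3-methylpyridin-2-yl to 3-nitropyridin-2-yl, with nitro in place of methyl on an aromatic carbon as the whole change. Going by the values given here, the only measured step at this place is a step that the limit leaves unreadable from compound 2 to compound 3 and there methoxycarbonyl takes the place of methyl, so no size can be carried over from it. Among the compounds with values here, compound 1 differs in more than one place and offers no step. Compound 3 gives 50.2 mg/kg and is the nearest guide, so a value of similar size is expected for the nitro compound. Compound 4 may also return only a limit. In this assay the expected step that the limit leaves unreadable from compound 2 to compound 4 is therefore small, with no firm direction. For compound 4 the estimated value is 55 mg/kg with an expected range from 25 mg/kg to 120 mg/kg in this measurement.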

Compound 4, dose for half-maximal effect: 43.6 mg/kg
Estimate against measurement, compound 4: 1.3-fold (0.10 log units) above; the range from low to high includes it.
By their numbers in this assay, from the lowest: compounds 4, 3 and 1 (each within the scatter of the next).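

In this assay, this aromatic carbon, ortho to a large group, now has two exact numbers to compare: replacing methoxycarbonyl with nitro gives a 1.2-fold lower number from compound 3 to compound 4 (0.06 log units; within the scatter), so the assay does not separate these two groups. On these data alone, replacing methyl with nitro gives an at least 1.1-fold lower number from compound 2 to compound 4 (0.05 log units; that floor lies within the scatter), which is only a floor on the size of the change, and the true step remains unknown. The step from compound 2 to compound 3 cannot be read, because compound 2 carries a limit rather than a number: the limit of > 50 mg/kg in this assay, at which 1 of the 4 values shown sits.

As far as these compounds go, it remains open whether this position can shift the dose at all, as the two exact values here lie within the scatter of each other. An amine or a carboxylic acid on the same carbon, or simply a hydrogen there, would test this more widely.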